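Trifluoromethyl to Methylsulfanyl: Expected Solubility of Compound 4

A few compounds are considered here, and "the series" means these few. Any claim that something is new, unique, unknown or untested is made for them only; others in the source may bear on it.

Compound 1 `Cc1cc(NC(=O)Nc2ccc(C(=O)O)cc2)c2ccccc2n1`: 9300 nM
Compound 2 `Cc1cc(NC(=O)Nc2ccccc2C(F)(F)F)c2ccccc2n1`: 3800 nM
Compound 3 `Cc1cc(NC(=O)Nc2ccc(F)cc2)c2ccccc2n1`: 3700 nM

In a physicochemical assay for solubility, at pH 7.4 (on this read-out lower numbers stand for lower solubility and higher numbers for higher solubility), compound 2 gives 3800 nM, the second highest of the three numbers. Compound 3, with 3700 nM, lies within the scatter of it, while compound 1, with 9300 nM, stands furthest away and beyond the scatter. Going by the values given here, the only measured single step, a 2.5-fold lower number from compound 1 to compound 3 (0.40 log units; beyond the scatter), concerns fluoro in place of carboxy and so does not bear on the change at hand. Compound 4 `CSc1ccccc1NC(=O)Nc1cc(C)nc2ccccc12` differs from compound 2 by methylsulfanyl in place of trifluoromethyl on an aromatic carbon. Among the compounds with values here, with no measured step informing this change, compound 4 is expected to stay close to compound 2 and is estimated at 4000 nM, with a range from 1500 nM to 10000 nM. The expected step is a 1.1-fold higher number from compound 2 to compound 4 (0.02 log units; within the scatter), within the scatter.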

Compound 4, solubility: 21000 nM
The estimate for compound 4 lay 5.3-fold (0.72 log units) below the measured number, and the stated range ends below it.
By their numbers in this assay, from the lowest: compounds 3 and 2 (each within the scatter of the next); then compound 1; then compound 4.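

In this assay, methylsulfanyl in place of trifluoromethyl on an aromatic carbon, ortho to a large group, gives a 5.5-fold higher number from compound 2 to compound 4 (0.74 log units; beyond the scatter). Going by these compounds alone, this is the first step measured at this place, and it shows that the read-out here responds to this exchange by more than the scatter. No measured evidence accounts for the size or direction of the step. Going by these compounds, whether a methoxy group, an amine or a longer chain such as ethylsulfanyl would give a similar step here remains open. So does whether methylsulfanyl would do the same elsewhere on the ring.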